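Replacing 3-iodophenyl with thiophen-2-yl: what to expect

The source may report more compounds than this note shows. Statements on the series, on what has been measured and on what is new or still open speak of the compounds shown alone.

Compound 1 `Oc1ccc(CN(Cc2cccc(C(F)(F)F)c2)Cc2ccc(O)c3ncccc23)c2cccnc12`: 38 nM
Compound 2 `Oc1ccc(CN(Cc2cccc(I)c2)Cc2ccc(O)c3ncccc23)c2cccnc12`: 350 nM

In a functional assay on A549 cells (Homo sapiens) for cytotoxicity, read by MTT assay (a lower number here means a stronger inhibitor, a higher number a weaker inhibitor), compound 2 gives 350 nM as the higher of the two numbers, so it is the weaker inhibitor of the pair. Compound 3 `Oc1ccc(CN(Cc2cccs2)Cc2ccc(O)c3ncccc23)c2cccnc12` is still unmeasured. Its change from compound 2 is thiophen-2-yl in place of 3-iodophenyl on a saturated chain carbon bound to an amine nitrogen and puts thiophen-2-yl in place of 3-iodophenyl on a saturated chain carbon bound to an amine nitrogen.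

Going by the values given here, only one measured step bears on this. It is a 9.2-fold higher number from compound 1 to compound 2 (0.96 log units; beyond the scatter) and comes from changing a single group on an aromatic carbon. Among the compounds with values here, no measured step replaces a whole ring, so the direction remains open. A step no larger than that one is expected, leaning slightly towards a lower number. The expected step is a 1.8-fold lower number from compound 2 to compound 3 (0.24 log units; within the scatter) and may stay within the scatter. For compound 3 the estimated value is 200 nM, with an expected range from 50 nM to 800 nM.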

Compound 3, half-maximal inhibitory concentration: 27 nM
Beside the measured number, compound 3's estimate is 7.4-fold (0.87 log units) above it; measured number below the stated range.
By their numbers in this assay, from the lowest: compounds 3 and 1 (each within the scatter of the next); then compound 2.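

In this assay, the change a 13-fold lower number from compound 2 to compound 3 (1.11 log units; beyond the scatter) shows that a whole ring can be exchanged on a saturated chain carbon bound to an amine nitrogen, with a five-membered sulfur-containing ring taking the place of a six-membered carbon ring, and that the number can fall sharply when this happens. The comparison a 1.4-fold lower number from compound 1 to compound 3 (0.15 log units; within the scatter) places thiophen-2-yl level with 3-(trifluoromethyl)phenyl, so a substituted benzene ring is not required at this position for a number as low as that of compound 1, and among these three compounds only the 3-iodophenyl compound stands apart. No available evidence explains the difference.

Going by these compounds, it remains open how an unsubstituted phenyl ring or a furan-2-yl ring would compare at this position. On these data alone, a thiophene ring carrying a carboxylic acid or an amine is equally open.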